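Para-Alkyl Growth on the Benzamide Ring: Ethyl to Tert-Butyl

This account rests on a few compounds, and the source may have more. Where it says the series, first, only, none or still open, it means among the compounds named here.

Three compounds have been measured in a functional assay on HepG2 cells (Homo sapiens) for inhibition, read by MTT assay; on this read-out lower numbers stand for stronger inhibition and higher numbers for weaker inhibition:
compound 1, `COc1cc2ncnc(Nc3ccc(NC(=O)c4cccc(C)c4)cc3)c2cc1OC`, 7500 nM
compound 2, `COc1cc2ncnc(Nc3ccc(NC(=O)c4ccc(C)cc4)cc3)c2cc1OC`, 25000 nM
compound 3, `CCc1ccc(C(=O)Nc2ccc(Nc3ncnc4cc(OC)c(OC)cc34)cc2)cc1`, 72000 nM

Compound 3 stands at the highest of the three numbers; the nearest is compound 2 and the furthest is compound 1, so compound 3 shows the weakest inhibition of the set in this assay.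

Compound 4, `COc1cc2ncnc(Nc3ccc(NC(=O)c4ccc(C(C)(C)C)cc4)cc3)c2cc1OC`, differs from compound 3 by one change: tert-butyl in place of ethyl on an aromatic carbon.

For the measured compounds named here, two measured steps bear on this. The step of a 2.9-fold higher number from compound 2 to compound 3 (0.46 log units; beyond the scatter) added one carbon to the chain at the same position and raised the number. The step of a 9.6-fold higher number from compound 1 to compound 3 (0.98 log units; beyond the scatter), which likewise ends at compound 3, pointed the same way, as did a 3.3-fold higher number from compound 1 to compound 2 (0.52 log units; beyond the scatter). Across these three compounds every extension at this carbon has weakened inhibition, with no compound going against it, though the set is small.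

Compound 4 adds two further carbons at that carbon, so an increase beyond the scatter is expected, of roughly the size a 2.1-fold higher number from compound 3 to compound 4 (0.32 log units; beyond the scatter). Compound 4 is therefore estimated at 150000 nM, within a range from 60000 nM to 400000 nM, with a real chance that the assay reports only a limit.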

Compound 4, half-maximal inhibitory concentration: > 100000 nM
Compound 4 gave a limit, no number; the forecaster's own chance of this, stated with the estimate: 35%; the middle value lies beyond the limit too.
By their numbers in this assay, from the lowest: compound 1; then compound 2; then compound 3. At a limit, above all of these: compound 4.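

In this assay compound 4 gives > 100000 nM, which is a limit and not a number, so tert-butyl on this aromatic carbon takes the series to the end of what the assay reports: the limit of > 100000 nM in this assay, at which 1 of the 4 values shown sits. Against ethyl the result gives only a floor, an at least 1.3-fold higher number from compound 3 to compound 4 (0.14 log units; that floor lies within the scatter), so this one change cannot be sized, and the compounds do not establish a real separation between ethyl and tert-butyl. For the compounds shown here, the wider comparisons do carry weight and extend what the earlier compounds showed, with an at least 4.0-fold higher number from compound 2 to compound 4 (0.60 log units; beyond the scatter) against the methyl group at the same carbon and an at least 13-fold higher number from compound 1 to compound 4 (1.12 log units; beyond the scatter) against the 3-methylphenyl group, the latter being the largest gap in this small set.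

On these data alone, how far compound 4 lies past its limit stays unknown, and so does whether tert-butyl differs at all from ethyl in this assay. The compounds shown also leave open whether any group at this carbon other than an alkyl group, such as methoxy, an amine or a carboxylic acid, would bring the number back down towards that of compound 1.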